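The compounds below may be only part of what the source reports. "The series", "measured", "known", "first", "only" and "open" are said of these compounds alone.

Measured so far:
compound 1 `Cc1ccc(COc2n[nH]c(=S)n2/N=C/c2c[nH]nc2-c2ccc(Cl)cc2)cc1`: 28 ug/mL
compound 2 `S=c1[nH]nc(OCc2ccccc2)n1/N=C/c1c[nH]nc1-c1ccc(Cl)cc1`: 18 ug/mL

In a functional assay on HepG2 cells (Homo sapiens) for cytotoxicity, read by MTT assay, with a stated time of 24 h (on this read-out higher numbers stand for weaker inhibition and lower numbers for stronger inhibition), compound 1 gives 28 ug/mL, the highest of the two numbers recorded. Within the data shown here, its nearest neighbour is compound 2, which gives 18 ug/mL in this assay, and the single step between measured compounds, a 1.6-fold lower number from compound 1 to compound 2 (0.19 log units; within the scatter), stays within the scatter of repeated measurements. Compound 3 `Cc1ccc(COc2n[nH]c(=S)n2/N=C/c2c[nH]nc2-c2ccc(F)cc2)cc1` differs from compound 1 by fluoro in place of chloro on an aromatic carbon, a halogen exchange at the far end of the molecule. Among the measured compounds shown here, no measured step concerns this exchange; the one step available touches a different part of compound 1 and was itself small. There is thus no basis in these numbers for expecting a shift beyond the scatter. For compound 3 the expected step is therefore a 1.1-fold higher number from compound 1 to compound 3 (0.03 log units; within the scatter), essentially none in this assay. Compound 3 is accordingly estimated at 30 ug/mL, with a range from 12 ug/mL to 75 ug/mL.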

Compound 3, half-maximal inhibitory concentration: 45 ug/mL
Estimate against measurement, compound 3: 1.5-fold (0.18 log units) below; low and high end bracket the measured number.
By their numbers in this assay, from the lowest: compounds 2, 1 and 3 (each within the scatter of the next, the first and the last beyond it).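

In this assay, among these compounds, replacing 4-chlorophenyl with 4-fluorophenyl gives a 1.6-fold higher number from compound 1 to compound 3 (0.21 log units; within the scatter), the first reading for a change at this position, as the earlier step concerned the methyl on the other side of the molecule. Here, chloro and fluoro cannot be told apart, since the difference between them is no larger than what repeated measurements of the same compound can show. No measurement at hand offers an explanation for this result.

The compounds shown leave open whether a group of another kind at this position, such as an amine, a methoxy group or a carboxylic acid, would shift the number beyond the scatter. They also leave open whether the same halogen exchange would read alike on compound 2, which lacks the methyl.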